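Ethyl in place of methyl on the sulfonamide of compound 3

The source may hold more compounds than are shown below. What is called first, only, known or untested is meant among the compounds shown, and "the series" means these compounds.

Measured compounds:
- Compound 1, `CCCC1C(=O)N(C)c2cnc(Nc3ccc(S(N)(=O)=O)cc3)nc2N1C`: 206 nM
- Compound 2, `CC(C)CC1C(=O)N(C)c2cnc(Nc3ccc(S(N)(=O)=O)cc3)nc2N1C`: 77 nM
- Compound 3, `CNS(=O)(=O)c1ccc(Nc2ncc3c(n2)N(C)C(c2ccccc2C)C(=O)N3C)cc1`: 104 nM

All three compounds were tested in an assay on Sf9 cells for inhibition of serine/threonine-protein kinase 4 (Homo sapiens), read by luminescence and ADP-Glo, with a stated time of 1 h, in the presence of a further agent that is not named here; on this read-out lower numbers stand for stronger inhibition and higher numbers for weaker inhibition. Compound 1 and compound 2 share one core and differ in a single spot, (methyl in place of hydrogen on a saturated chain carbon bound to two saturated chain carbons). In this assay compound 1 gives 206 nM and compound 2 gives 77 nM, so the step is a 2.7-fold lower number from compound 1 to compound 2 (0.43 log units; beyond the scatter).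

Compound 3 has a different core; the difference between the two cores is not broken down here. In this assay compound 3 gives 104 nM, which is within the scatter of both compound 2 and compound 1.

Compound 4, `CCNS(=O)(=O)c1ccc(Nc2ncc3c(n2)N(C)C(c2ccccc2C)C(=O)N3C)cc1`, has not yet been measured. It differs from compound 3 by methyl in place of hydrogen on a saturated chain carbon bound to a sulfonamide nitrogen. Going by the values given here, this is the same kind of change as the one from compound 1 to compound 2, but not the same: there the added methyl sits on a saturated chain carbon bound to two saturated chain carbons, whereas here it sits on a saturated chain carbon bound to a sulfonamide nitrogen. Among the compounds with values here, because the only measured example is a 2.7-fold lower number from compound 1 to compound 2 (0.43 log units; beyond the scatter), and its place differs from this one, a smaller step is expected from compound 3 to compound 4, one that may well stay within the scatter: a 1.2-fold lower number from compound 3 to compound 4 (0.06 log units; within the scatter). Compound 4 is therefore estimated at 90 nM, with a range from 40 nM to 200 nM.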

Compound 4, half-maximal inhibitory concentration: 119 nM
Beside the measured number, compound 4's estimate is 1.3-fold (0.12 log units) below it, within the range that was stated.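

In this assay, methyl in place of hydrogen on a saturated chain carbon bound to a sulfonamide nitrogen gives a 1.1-fold higher number from compound 3 to compound 4 (0.06 log units; within the scatter), so compound 3 and compound 4 cannot be told apart on this read-out. A change of the same kind therefore does not bring a step of the same size in both pairs of compounds: the same change on two cores in this assay, a 2.7-fold lower number (0.43 log units; beyond the scatter) from compound 1 to compound 2 and a 1.1-fold higher number (0.06 log units; within the scatter) from compound 3 to compound 4, 3.1-fold (0.49 log units) apart, beyond the scatter of two such steps This does not show that the core alone sets the two steps apart: the pairs differ in their core and also in where the methyl is added, each step rests on a single pair, and the data cannot separate these two differences.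

The compounds shown leave open how the same methyl step on the sulfonamide would read on the core of compound 1, and how the step on a saturated chain carbon bound to two saturated chain carbons would read on the core of compound 3; such matched pairs would separate the effect of the core from that of the place. Also open, on these data alone, is what a longer chain such as propyl on the sulfonamide nitrogen, or an amine or a hydroxyl group at the end of the ethyl chain, would do to the number.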